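The source may report more compounds than this note shows. Statements on the series, on what has been measured and on what is new or still open speak of the compounds shown alone.

Compound 1 `CC(C)N(Cc1cccc(OCCCCCC(=O)O)c1)C(=O)c1ccc(-c2ccc3[nH]ccc3c2)cc1` and compound 2 `CC(C)N(Cc1cccc(OCCCCCC(=O)O)c1)C(=O)c1ccc(-c2cccc(C(F)(F)F)c2)cc1` share one core and differ only at the far end. In an ADME assay on HEK293 cells (Homo sapiens) for cytotoxicity, read by CellTiter-Glo and resazurin assay, with a stated time of 72 h (on this read-out lower numbers stand for an effect already at smaller amounts and higher numbers for an effect only at larger amounts of compound), compound 1 gives > 26000 nM, which is a limit of the assay and not a number. Compound 2 gives > 26000 nM in this assay, again a limit rather than a number. The step that the two limits leave unreadable from compound 1 to compound 2 therefore cannot be read, since both values sit at the limit of > 26000 nM in this assay, at which 2 of the 2 values shown sit. Among the measured compounds shown here, compound 2 thus stands at the limit, alongside the only other value shown. Compound 3 `CC(C)N(Cc1cccc(OCCCCCC(=O)O)c1)C(=O)c1ccc(-c2cccc([N+](=O)[O-])c2)cc1` carries the change (nitro in place of trifluoromethyl on an aromatic carbon). For the measured compounds named here, no measured step gives a readable size for this kind of change, so no shift beyond the usual scatter is expected in this assay, in either direction. The expectation thus amounts to a step that the limit leaves unreadable from compound 2 to compound 3 that stays within the scatter. Compound 3 is accordingly expected to give about 40000 nM, between 15000 nM and 120000 nM, most likely again only as a limit.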

Compound 3, half-maximal effective concentration: > 26000 nM
Compound 3 was reported as a limit; the forecaster's own chance of this, stated with the estimate: 75%; the middle value lies beyond the limit too.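

Among the compounds shown here, compound 1, compound 2 and compound 3 all give a limit rather than a number, so no step among them can be read in this assay: the limit of > 26000 nM in this assay, at which 3 of the 3 values shown sit. The compounds shown leave open whether these three differ at all in this assay, and at what amount each would show an effect.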